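Cyano in place of trifluoromethyl on the benzylidene ring

The source may report more compounds than this note shows. Statements on the series, on what has been measured and on what is new or still open speak of the compounds shown alone.

Compound 1 `CCCCCC1(OC)CCN(c2ccc(C(=O)NS(=O)(=O)c3ccc(N[C@H](CCN(C)C)CSc4ccccc4)c([N+](=O)[O-])c3)cc2)CC1` gives 3000 nM in a functional assay (FL5.12 cells, Mus musculus) with Apoptosis regulator Bcl-2 (Homo sapiens) as the target; on this read-out lower numbers stand for an effect already at smaller amounts and higher numbers for an effect only at larger amounts of compound.
Compound 2 `CN(C)CC[C@H](CSc1ccccc1)Nc1ccc(S(=O)(=O)NC(=O)c2ccc(N3CCC(=Cc4ccccc4C(F)(F)F)CC3)cc2)cc1[N+](=O)[O-]` gives 210 nM in this assay.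

Of the two compounds measured, compound 2 stands at the lower number in this assay, and its gap to compound 1 lies beyond the scatter. Compound 3 `CN(C)CC[C@H](CSc1ccccc1)Nc1ccc(S(=O)(=O)NC(=O)c2ccc(N3CCC(=Cc4ccccc4C#N)CC3)cc2)cc1[N+](=O)[O-]` is not yet measured; it differs from compound 2 by one change: cyano in place of trifluoromethyl on an aromatic carbon. Going by the values given here, no measured pair shows this change, so the data give no direct guide to its size. The step from compound 2 to compound 3 is expected to be small, within the scatter, as a 1.4-fold higher number from compound 2 to compound 3 (0.15 log units; within the scatter). For compound 3 the estimated value in this assay is 300 nM, with a range from 100 nM to 900 nM.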

Compound 3, half-maximal effective concentration: 1600 nM
For compound 3 the middle estimate is 5.3-fold (0.73 log units) below the measured one; measured number above the stated range.
By their numbers in this assay, from the lowest: compound 2; then compounds 3 and 1 (each within the scatter of the next).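

In this assay, cyano in place of trifluoromethyl on this aromatic carbon, ortho to a large group, brings a 7.6-fold higher number from compound 2 to compound 3 (0.88 log units; beyond the scatter) and so loses much of the effect. The position therefore distinguishes between these two groups, with 2-(trifluoromethyl)phenyl the better of the pair. Nothing in the available data accounts for the step. Open, from the compounds shown here alone, is where other groups on this carbon, such as chlorine, methyl or methoxy, would fall relative to compound 2 and compound 3. Also open, going by these compounds, is whether an amine or a carboxylic acid would be accepted here.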